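Ester to acid within a single triazole series

A few compounds are considered here, and "the series" means these few. Any claim that something is new, unique, unknown or untested is made for them only; others in the source may bear on it.

Compound 1 `COC(=O)c1cc(-n2cc(-c3cc(OC)cc(OC)c3)nn2)ccc1O` gives 3% in a functional assay on HCT-116 cells (Homo sapiens) for inhibition, read by MTT assay, with a stated time of 2 days, tested at 10 uM; on this read-out lower numbers stand for less inhibition and higher numbers for more inhibition at the one concentration tested (going by the name of the read-out). Compound 3 `COC(=O)c1cc(-n2cc(-c3ccc(OC)cc3)nn2)ccc1O` gives 6% in this assay, and compound 2 `COc1ccc(-c2cn(-c3ccc(O)c(C(=O)O)c3)nn2)cc1` gives 8% in this assay. All three numbers lie within the scatter of one another, so no ordering among them is drawn. The difference between the core of compound 1 and the core of compound 3 is not broken down here.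

Between compound 3 and compound 2 the change is hydrogen in place of methyl on an oxygen next to a carbonyl group, and the step is a number 2 percentage points higher from compound 3 to compound 2 (within the scatter).

Compound 4 `COc1cc(OC)cc(-c2cn(-c3ccc(O)c(C(=O)O)c3)nn2)c1` differs from compound 1 by hydrogen in place of methyl on an oxygen next to a carbonyl group, the same change at the same place, made on the core of compound 1 instead of the core of compound 3.

The step from compound 1 to compound 4 in this assay is expected to be a number 2 percentage points higher from compound 1 to compound 4 (within the scatter), resting on the step of a number 2 percentage points higher from compound 3 to compound 2 (within the scatter), which stayed within the scatter. Compound 4 is therefore estimated at 5% in this assay, with a range from -5% to 15%.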

Compound 4, a percentage reported as inhibition, at one concentration (the size of the read-out at that concentration, not a potency): 2%
Compound 4: middle estimate off by 3 percentage points, on the high side, within the range that was stated.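

On the core of compound 1, hydrogen in place of methyl on an oxygen next to a carbonyl group gives a number 1 percentage points lower from compound 1 to compound 4 (within the scatter) in this assay. Set beside the same change on the core of compound 3, the two steps do not differ: the same change on two cores in this assay, a number 2 percentage points higher (within the scatter) from compound 3 to compound 2 and a number 1 percentage points lower (within the scatter) from compound 1 to compound 4, 3 percentage points apart, within the scatter of two such steps This shows that methoxycarbonyl to carboxy carries across these two cores without a step that can be told from the scatter, but it does not show that the change has the same real effect on both, since neither step lies beyond the scatter and a flat result on two cores says little about how the change would carry on a core with a larger read-out.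

Open, from the compounds shown here alone, is whether an amide or a longer ester chain in place of the methoxycarbonyl would give a step beyond the scatter in this assay. Also open, going by these compounds, is whether an amine or a halogen in place of the methoxy groups of the cores would change this picture.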